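The compounds below may be only part of what the source reports. "The series", "measured", "known", "first", "only" and "open" are said of these compounds alone.

Measured compounds:

Compound 1, `COC(=O)/C=C/c1cccc(N(Cc2ccc(/C=C/c3ccccc3F)cc2)C(=O)NC(C)C)c1`: 431 nM
Compound 2, `COC(=O)/C=C/c1cccc(N(Cc2ccc(/C=C/c3ccc(F)cc3)cc2)C(=O)C(C)C)c1`: 120 nM
Compound 3, `COC(=O)/C=C/c1cccc(N(Cc2ccc(-c3ccc(OC)cc3)cc2)C(=O)C2CCCCC2)c1`: 89 nM

All three were tested in an assay on isolated protein with Bile acid receptor (Homo sapiens) as the target; a lower number here means that less compound is needed, a higher number that more compound is needed for the effect. Compound 2 gives the second highest of the three numbers. Its nearest neighbour is compound 3, whose value sits within the usual scatter of compound 2, so the two cannot be ranked against each other. Compound 1 lies further off, with a higher number than compound 2 that falls beyond the scatter.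

The step studied here leads from compound 2 to the unmeasured compound 4, `COC(=O)/C=C/c1cccc(N(Cc2ccc(-c3cccc(C)c3)cc2)C(=O)C(C)C)c1`. The two structures differ in one place: 3-methylphenyl in place of 2-(4-fluorophenyl)ethenyl on an aromatic carbon. The shared core and the isobutyryl-type amide stay the same.

Among the compounds with values here, no step between two measured compounds isolates this particular change, so the expectation rests on the picture as a whole. Compound 3 carries a directly attached aromatic ring in the same region and gives 89 nM, a number within the scatter of compound 2. On that basis a small step is expected for compound 4 in this assay, with no clear direction beyond the scatter, as the estimated step of a 1.4-fold higher number from compound 2 to compound 4 (0.15 log units; within the scatter) expresses. Compound 4 is therefore expected to give about 170 nM in this assay, within a range of 60 nM to 500 nM.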

Compound 4, half-maximal effective concentration: 163 nM
For compound 4 the middle estimate is 1.0-fold (0.02 log units) above the measured one; the range from low to high includes it.
By their numbers in this assay, from the lowest: compounds 3, 2 and 4 (each within the scatter of the next); then compound 1.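

In this assay, within the data shown here, putting 3-methylphenyl in place of 2-(4-fluorophenyl)ethenyl, on an aromatic carbon para to a large group, gives a 1.4-fold higher number from compound 2 to compound 4 (0.13 log units; within the scatter), and this is the first change at this position that can be read on its own. The entering group has no double bond outside its aromatic ring and no fluorine, yet the step stays within the usual scatter, so in this pair neither loss comes with a difference that can be told apart from repeat measurement. No measurement at hand speaks to the reason for this outcome.

A single pair says little about the wider range of groups that this position accepts, and it cannot separate the contribution of the methyl group from that of the ring that carries it. On these data alone, whether a plain phenyl ring would read the same, and whether a carboxylic acid or an amine on the outer ring would move the number beyond the scatter, remains open.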